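The source may hold more compounds than are shown below. What is called first, only, known or untested is meant among the compounds shown, and "the series" means these compounds.

Series notes, amide-side aryl variation.

Three compounds carry a number in a functional assay on HT-29 cells (Homo sapiens) for cytotoxicity, read by MTT assay, with a stated time of 72 h; on this read-out lower numbers stand for stronger inhibition and higher numbers for weaker inhibition. Compound 1 `O=C(CN1CCN(c2nnc(Cc3ccncc3)c3ccccc23)CC1)Nc1ccc(F)c(Cl)c1` gives 880 nM. Among the compounds with values here, compound 2 `O=C(CN1CCN(c2nnc(Cc3ccncc3)c3ccccc23)CC1)Nc1ccc(Br)cc1` gives 1990 nM; the single step of a 2.3-fold higher number from compound 1 to compound 2 (0.35 log units; beyond the scatter) is the only measured exchange on the amide-type nitrogen. Compound 3 `COc1ccc(NC(=O)CN2CCN(c3nnc(Cc4ccccc4)c4ccccc34)CC2)cc1OC` gives 145000 nM and stands as the weakest of the three, far above both compound 2 and compound 1. Within the data shown here, compound 3 also differs from compound 1 and compound 2 in more than one place, so no single step connects it to them and the gap cannot be assigned to one part of the molecule.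

Compound 4 `Cc1ccccc1NC(=O)CN1CCN(c2nnc(Cc3ccccc3)c3ccccc23)CC1` shares the core of compound 3 and differs from it only in the change (2-methylphenyl in place of 3,4-dimethoxyphenyl on an amide-type nitrogen). Among the measured compounds shown here, the one measured exchange at this position, from compound 1 to compound 2, was modest and lay only just beyond the scatter. For the measured compounds named here, nothing among the measured compounds shows the methoxy groups or the methyl group on this ring in a single step, so the direction is open; a step of modest size in this assay is the reasonable expectation for compound 4, if anything a slightly lower number, as a 1.8-fold lower number from compound 3 to compound 4 (0.26 log units; within the scatter) states.

Compound 4 is therefore estimated at 80000 nM, with a range from 15000 nM to 300000 nM.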

Compound 4, half-maximal inhibitory concentration: 113000 nM
Beside the measured number, compound 4's estimate is 1.4-fold (0.15 log units) below it, within the range that was stated.
By their numbers in this assay, from the lowest: compound 1; then compound 2; then compounds 4 and 3 (each within the scatter of the next).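

In this assay, within the data shown here, the exchange of 3,4-dimethoxyphenyl for 2-methylphenyl on the amide-type nitrogen gives a 1.3-fold lower number from compound 3 to compound 4 (0.11 log units; within the scatter) and is the first measured step at this position on the core of compound 3, where the two aryl groups cannot be told apart. The change takes the group from 10 heavy atoms to 7 and from 2 hydrogen-bond acceptors to 0, including the loss of both oxygen atoms, yet the numbers remain within the scatter of each other, unlike the exchange on the core of compound 1, a 2.3-fold higher number from compound 1 to compound 2 (0.35 log units; beyond the scatter), which lies just beyond it. No measurement at hand accounts for either step.

Among these compounds, whether the high numbers of compound 3 and compound 4 belong to the amide-side aryl group or to another part of the molecule stays open, as no single step links either of them to compound 1 or compound 2. Also open, as far as these compounds go, are whether a dimethylamino group or a carboxylic acid on this aryl ring would move the number on the core of compound 3 beyond the scatter, and how 2-methylphenyl would read on the core of compound 1.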